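A few compounds are considered here, and "the series" means these few. Any claim that something is new, unique, unknown or untested is made for them only; others in the source may bear on it.

Measured so far:
compound 1 `CC1=NN(C(=O)c2ccc(C)cc2)C(c2cc(Br)ccc2O)C1` gives 41200 nM
compound 2 `CCN(CC)CC(=O)N1N=C(C)CC1c1ccccc1O` gives 25900 nM
compound 3 `O=C(c1ccccc1)N1N=C(c2cc3ccccc3oc2=O)CC1c1ccccc1` gives 5870 nM

The series is read in a functional assay on PC-3 cells (Homo sapiens) for cytotoxicity, read by MTT assay, with a stated time of 48 h; a higher number here means a weaker inhibitor, a lower number a stronger inhibitor. On these numbers compound 3 stands lowest of the three and is the strongest inhibitor shown, with both other compounds beyond the scatter from it: compound 2 is the nearest, and compound 1 the furthest. Going by the values given here, no two of the three measured compounds differ in only one place, so no single step within the measured set can be isolated; compound 2 and compound 3 both carry an acyl group on the ring nitrogen, but they differ elsewhere as well, and their values show only that compound 3 sits well below compound 2 in this assay.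

The next compound, compound 4 `CCCNCC(=O)N1N=C(c2cc3ccccc3oc2=O)CC1c1ccccc1`, keeps the core of compound 3 and changes only the acyl group: (propylamino)methyl in place of phenyl on a carbonyl carbon. Nothing in the measured set tests this exchange on an otherwise identical scaffold. A step in this assay of modest size, toward a higher number and so a weaker inhibitor, is expected from compound 3 to compound 4, though a step within the scatter cannot be excluded. Compound 4 is therefore estimated at 9000 nM, with a range from 2500 nM to 35000 nM, and the expected step is a 1.5-fold higher number from compound 3 to compound 4 (0.19 log units; within the scatter).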

Compound 4, half-maximal inhibitory concentration: 7270 nM
Estimate against measurement, compound 4: 1.2-fold (0.09 log units) above; low and high end bracket the measured number.
By their numbers in this assay, from the lowest: compounds 3 and 4 (each within the scatter of the next); then compounds 2 and 1 (each within the scatter of the next).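

Going by these compounds alone, on the core shared by compound 3 and compound 4, the earlier compounds offered no single exchange at the acyl group; this pair now supplies one. In this assay, (propylamino)methyl in place of phenyl on a carbonyl carbon gives a 1.2-fold higher number from compound 3 to compound 4 (0.09 log units; within the scatter) and so leaves the two compounds indistinguishable in this read-out. On this core, then, benzoyl and ((propylamino)methyl)carbonyl cannot be told apart here, even though the exchange removes a six-membered aromatic ring of carbon only and brings in an open chain with a hydrogen-bond donor and a hydrogen-bond acceptor, and nothing shown bears on the reason for this result.

The compounds shown leave open whether the same position would tolerate a cyclic amine such as morpholine, a carboxylic acid or a longer chain on the nitrogen, since a single exchange gives no trend at this position. They also leave open whether the result would carry over to the cores of compound 1 and compound 2, neither of which has a partner that differs from it in only one place.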